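Acetyl in place of sulfoximine: the step to compound 4

The source may hold more compounds than are shown below. What is called first, only, known or untested is meant among the compounds shown, and "the series" means these compounds.

Compound 1 `CC#C[C@H]1CN(S(=O)(=O)c2ccc(N)nc2)CCN1c1ccccc1` carries only a hydrogen at one aromatic carbon of the shared core. In an ADME assay (liver) for metabolic stability, with Liver microsome (Rattus norvegicus) as the target, using microsomes and NADPH, with a stated time of 30 min (on this read-out lower numbers stand for slow clearance and higher numbers for fast clearance), compound 1 gives > 399 mL.min-1.g-1, a limit of the assay rather than a number. Compound 2 `CC#C[C@H]1CN(S(=O)(=O)c2ccc(N)nc2)CCN1c1ccc(S(=N)(=O)C2CC2)cc1` carries a cyclopropyl sulfoximine at that carbon, and in this assay compound 2 gives 23 mL.min-1.g-1. Compound 3 `CC#C[C@H]1CN(S(=O)(=O)c2ccc(N)nc2)CCN1c1ccc(S(C)(=N)=O)cc1` carries the methyl counterpart, and in this assay compound 3 gives < 14 mL.min-1.g-1, again a limit rather than a number. Two steps are large: an at least 17-fold lower number from compound 1 to compound 2 (1.23 log units; beyond the scatter) and an at least 28-fold lower number from compound 1 to compound 3 (1.45 log units; beyond the scatter). By contrast, an at least 1.6-fold lower number from compound 2 to compound 3 (0.21 log units; that floor lies within the scatter). Compound 3 therefore sits at the limit of < 14 mL.min-1.g-1 in this assay, at which 1 of the 3 values shown sits, while compound 1 sits at the limit of > 399 mL.min-1.g-1 in this assay, at which 1 of the 3 values shown sits.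

Compound 4 `CC#C[C@H]1CN(S(=O)(=O)c2ccc(N)nc2)CCN1c1ccc(C(C)=O)cc1` has not yet been measured. The change from compound 3 is
a group of 3 heavy atoms (2 carbon, 1 oxygen; no ring) in place of a group of 4 heavy atoms (1 carbon, 1 nitrogen, 1 oxygen, 1 sulfur; no ring), on an aromatic carbon
The measured steps show that adding a group at this carbon lowers the number strongly, and that swapping methyl for cyclopropyl within that group changed little. Compound 4 keeps a group at the same place but of a different kind, so I expect a moderate rise: an at least 2.8-fold higher number from compound 3 to compound 4 (0.45 log units; beyond the scatter). Compound 4 is thus estimated at 40 mL.min-1.g-1, with a range from 14 mL.min-1.g-1 to 150 mL.min-1.g-1.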

Compound 4, intrinsic clearance in microsomes: 249 mL.min-1.g-1
For compound 4 the middle estimate is 6.2-fold (0.79 log units) below the measured one, outside the stated range (above it).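

In this assay, acetyl on the same aromatic carbon gives an at least 17-fold higher number from compound 3 to compound 4 (1.25 log units; beyond the scatter) and an 11-fold higher number from compound 2 to compound 4 (1.03 log units; beyond the scatter). So a group at this carbon does not by itself bring a low number, as the earlier compounds might have suggested: among the groups shown, the two sulfoximines in compound 2 and compound 3 give low numbers, while acetyl in compound 4 does not. Acetyl in place of hydrogen gives only an at least 1.6-fold lower number from compound 1 to compound 4 (0.20 log units; that floor lies within the scatter), and this is a floor, since the value of compound 1 is a limit of the assay.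

Still open, as far as these compounds go, is which part of the sulfoximine goes with the low numbers, something a methyl sulfone or a carboxamide at this carbon could help separate. The limit for compound 3 also leaves the full size of its step to compound 4 unknown.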